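The source may report more compounds than this note shows. Statements on the series, on what has been measured and on what is new or still open speak of the compounds shown alone.

Measured so far in a functional assay on A549 cells (Homo sapiens) for cytotoxicity, with a stated time of 48 h; a lower number here means a stronger inhibitor, a higher number a weaker inhibitor:

compound 1 `C[S+]([O-])/C=C/c1cc(=O)c2cc(O)ccc2o1` gives 10500 nM

compound 2 `COc1ccc2c(=O)cc(/C=C/[S+](C)[O-])oc2c1` gives 2200 nM

compound 3 `Cc1c(/C=C/[S+](C)[O-])oc2ccccc2c1=O` gives 1500 nM

Compound 1 has the highest number of the three in this assay, so it is the weakest of this small group. Compound 2 sits nearest to it, yet its number is lower by a margin beyond the usual scatter, and compound 3 lies still further away, also beyond the scatter. Among the measured compounds shown here, none of the three compounds differs from another in only one place, so no single structural step can be read off from the numbers so far.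

Compound 4 `COc1ccc2oc(/C=C/[S+](C)[O-])cc(=O)c2c1` is the next compound to be measured. It differs from compound 1 in one place: methyl in place of hydrogen on an oxygen on an aromatic ring. Read one bond further out, this is a change from hydroxy to methoxy.

For the measured compounds named here, no measured pair shows this exact change, so the direction rests on judgement alone. The two compounds with lower numbers, compound 2 and compound 3, both lack a free hydroxy group on the shared core, which hints that removing it may help rather than hurt. The expected step for a 2.3-fold lower number from compound 1 to compound 4 (0.37 log units; beyond the scatter) is therefore a modest move toward a lower number, though it may fall within the scatter. For compound 4 the estimate in this assay is 4500 nM, with a likely range from 1500 nM to 13000 nM.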

Compound 4, half-maximal inhibitory concentration: 1600 nM
The estimate for compound 4 lay 2.8-fold (0.45 log units) above the measured number, and the stated range covers the measured number.
By their numbers in this assay, from the lowest: compounds 3, 4 and 2 (each within the scatter of the next); then compound 1.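

In this assay, among the compounds shown here, placing a methyl on the oxygen of the hydroxy group of compound 1 gives a 6.6-fold lower number from compound 1 to compound 4 (0.82 log units; beyond the scatter) and provides the first step in this small set that can be traced to a single change. At this position, a free hydroxy group is therefore not required for activity against these cells, and the methoxy compound is the stronger of the two. Nothing measured here explains the size of this step.

From the compounds shown here alone, the comparison covers only hydrogen and methyl on this oxygen, so it remains open whether an ethyl group or a longer chain there would lower the number further or raise it. Going by these compounds, it is also open how an amine in place of the hydroxy group would compare.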